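The source may hold more compounds than are shown below. What is called first, only, known or untested is meant among the compounds shown, and "the series" means these compounds.

Of the compounds shown here, three with a shared core have been measured in a functional assay on HEK293 cells for agonist activity at D(4) dopamine receptor (Homo sapiens), read by FLIPR; on this read-out lower numbers stand for smaller maximal responses and higher numbers for larger maximal responses. Compound 1 `O=C(NCN1CCC(c2cccc[n+]2[O-])CC1)c1ccccc1` gives 63% in this assay. Compound 2 `O=C(CN1CCC(c2cccc[n+]2[O-])CC1)Nc1ccc(F)cc1F` gives 74%, and compound 3 `Cc1cc(Cl)cc(C)c1NC(=O)CN1CCC(c2ccccn2)CC1` gives 50%. Among these three numbers compound 1 stands second highest: the nearest value, that of compound 2, lies higher by a margin beyond the usual scatter, and the furthest, that of compound 3, lies lower, also beyond the scatter.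

Compound 4 `O=C(NCN1CCC(c2cccc[n+]2[O-])CC1)c1cc(Cl)cc(Cl)c1` has not yet been measured. It differs from compound 1 in one place: 3,5-dichlorophenyl in place of phenyl on a carbonyl carbon. Among the compounds with values here, none of the measured pairs differ in only one place, so no measured step speaks directly to this change. Compound 4 is therefore expected to give a value near that of compound 1, with a step of a number 3 percentage points lower from compound 1 to compound 4 (within the scatter) that may fall within the scatter in either direction. The estimate for compound 4 in this assay is 60%, with a range from 40% to 80%.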

Compound 4, largest response reached (reported as efficacy), in percent of the reference or control that the assay uses: 64%
The estimate for compound 4 lay 4 percentage points below the measured number; measured number inside the range.
By their numbers in this assay, from the lowest: compound 3; then compounds 1, 4 and 2 (each within the scatter of the next, the first and the last beyond it).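

Exchanging phenyl for 3,5-dichlorophenyl on a carbonyl carbon gives, in this assay, a number 1 percentage points higher from compound 1 to compound 4 (within the scatter). Within the data shown here, this is the first step here that isolates a single change, and it shows that at this place the two added chlorine atoms, which raise the group from 6 to 8 heavy atoms, leave the maximal response indistinguishable from that of the unsubstituted phenyl. Nothing available gives a reason for this outcome.

The compounds shown leave open whether other groups at this place, such as a single chlorine, a methoxy group or a carboxylic acid on the phenyl, or a pyridine ring in its stead, would also stay within the scatter. They also leave open whether 3,5-dichlorophenyl would behave the same way on a compound with a different chain to the amide nitrogen, such as a longer chain.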